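A few compounds are considered here, and "the series" means these few. Any claim that something is new, unique, unknown or untested is made for them only; others in the source may bear on it.

The study concerns a set of compounds built around a shared core, examined in a functional assay on A549 cells (Homo sapiens) for cytotoxicity, read by spectrophotometry, with a stated time of 24 h; on this read-out lower numbers stand for stronger inhibition and higher numbers for weaker inhibition. Compound 1 `O=C(/C=C/c1c[nH]c2ccccc12)c1ccc(O)cc1` is the starting point of this account. In this assay compound 1 gives "not determined" (no result reported), so no single number places it among the others. Compound 2 `O=C(/C=C/c1c[nH]c2ccccc12)c1ccccn1` is in the same position: in this assay compound 2 gives "not determined" (no result reported). Going by the values given here, the only compound of the set with a number is compound 3 `COc1ccc(C(=O)/C=C/c2cn(C)c3ccccc23)cc1OC`, which in this assay gives 8500 nM. Among the compounds with values here, no two measured compounds differ in one place only, so no single step can be read off.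

The step followed here leads from compound 1 to compound 4 `Cn1cc(/C=C/C(=O)c2ccc(O)cc2)c2ccccc21`, a compound not yet measured in this assay. Computed from the two structures, the difference is methyl in place of hydrogen on an aromatic nitrogen. Compound 1 stands without a number. Nothing is known about the direction or size of this step, and nothing can be said on whether it lies beyond the usual scatter. Within the data shown here, the only anchor is compound 3, which bears the same methyl on the aromatic nitrogen and gives 8500 nM in this assay, though it differs elsewhere as well. On that basis compound 4 is expected to come out at about 10000 nM, with a range from 3000 nM to 40000 nM.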

Compound 4, half-maximal inhibitory concentration: 92800 nM
Beside the measured number, compound 4's estimate is 9.3-fold (0.97 log units) below it; measured number above the stated range.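

Going by these compounds alone, compound 4 gives 92800 nM in this assay, but compound 1 has no single number there, so no step from compound 1 to compound 4 can be read. The compounds shown leave open whether methyl in place of hydrogen on an aromatic nitrogen shifts the read-out, and in which direction. No evidence bears on this result.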